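Hydroxyphenyl ring placement and topoisomerase inhibition

The compounds below may be only part of what the source reports. "The series", "measured", "known", "first", "only" and "open" are said of these compounds alone.

Measured compounds:
compound 1 `Oc1ccc(-c2cc(-c3cccs3)cc(-c3ccccc3O)n2)cc1`, 2%
compound 2 `Oc1cccc(-c2cc(-c3cccs3)cc(-c3cccc(O)c3)n2)c1`, 0%
compound 3 `Oc1ccc(-c2cc(-c3cccs3)cc(-c3cccc(O)c3)n2)cc1`, 1.1%

In an assay on isolated protein for inhibition of DNA topoisomerase 1 (Homo sapiens), with a stated time of 30 min, tested at 20 uM (on this read-out lower numbers stand for a weaker effect and higher numbers for a stronger effect at the one concentration tested), compound 3 gives 1.1%, which is the second highest of the three numbers; the gap to compound 1 and the gap to compound 2 both lie within the scatter, so no order among the three can be read. All three compounds share the same core and differ only in where the hydroxyl sits on one of the phenyl rings.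

Compound 4 `Oc1ccc(-c2cc(-c3cccs3)cc(-c3ccc(O)cc3)n2)cc1` has not yet been measured. The change from compound 3 to compound 4 is 4-hydroxyphenyl in place of 3-hydroxyphenyl on an aromatic carbon. Two measured steps move a hydroxyl on a phenyl ring of this core and therefore bear on it: a number 0.9 percentage points lower from compound 1 to compound 3 (within the scatter) and a number 1.1 percentage points higher from compound 2 to compound 3 (within the scatter). Both are within the scatter, and both neighbours of compound 3 sit at the same low level. Among the measured compounds shown here, no step in this set shifts this assay beyond the scatter, so the step to compound 4 is expected to be of the same kind, a number 0.4 percentage points higher from compound 3 to compound 4 (within the scatter), with no direction beyond the scatter. Compound 4 is therefore estimated at 1.5%, in the range -3% to 7%.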

Compound 4, a percentage reported as inhibition, at one concentration (the size of the read-out at that concentration, not a potency): 0.9%
For compound 4 the middle estimate is 0.6 percentage points above the measured one; the range from low to high includes it.
By their numbers in this assay, from the lowest: compounds 2, 4, 3 and 1 (each within the scatter of the next).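

Compound 4 brings the last of the three hydroxyl placements to the carbon next to the ring nitrogen, with a 4-hydroxyphenyl group kept elsewhere on the shared core. In this assay the read-out shows a number 0.2 percentage points lower from compound 3 to compound 4 (within the scatter) and also a number 1.1 percentage points lower from compound 1 to compound 4 (within the scatter) for the change from the 2-hydroxyphenyl group. With the 2-hydroxyphenyl, 3-hydroxyphenyl and 4-hydroxyphenyl groups now all seen at this place, moving the hydroxyl around this ring separates none of compounds 1, 3 and 4 beyond the scatter, and the new symmetrical compound 4 does not stand apart from them. No supporting data are at hand that would bear on this flat result.

The compounds shown leave open whether anything other than a hydroxyl on these phenyl rings, such as a methoxy group, an amine or a carboxylic acid, would move the read-out in this assay beyond the scatter. They also leave open whether a different ring or a longer chain in place of the thiophen-2-yl group would change the picture, since that group is the same in all four compounds.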